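A few compounds are considered here, and "the series" means these few. Any claim that something is new, unique, unknown or untested is made for them only; others in the source may bear on it.

Measured so far:
- compound 1, `COc1ccc(-c2nc(-c3ccccc3)c(-c3ccc4c(c3)NC(=O)CO4)[nH]2)cc1`: 96%
- compound 2, `O=C1COc2ccc(-c3nn(-c4ccc(Cl)cc4)cc3-c3ccccc3)cc2N1`: 61.9%
- compound 3, `O=C1COc2ccc(-c3nn(-c4ccccc4)cc3-c3ccccc3)cc2N1`: 77%

In a functional assay on DLD-1 cells (Homo sapiens) for cytotoxicity, read by colorimetric assay and MTT assay, with a stated time of 3 days, tested at 1 uM (on this read-out higher numbers stand for a weaker effect at the one concentration tested and lower numbers for a stronger effect), compound 1 gives the highest of the three numbers, so at the one concentration tested it shows the weakest effect; compound 3 comes nearest, and compound 2 lies furthest below it. Compound 4, `O=C1COc2ccc(-c3[nH]c(-c4ccc(Cl)cc4Cl)nc3-c3ccccc3)cc2N1`, is the next step from compound 1: 2,4-dichlorophenyl in place of 4-methoxyphenyl on an aromatic carbon. Among the measured compounds shown here, only one measured step speaks to a chloro substituent on this kind of pendant ring. Between compound 2 and compound 3, whose shared core differs from that of compound 1, the step was a number 15.1 percentage points higher from compound 2 to compound 3 (beyond the scatter), so taking a chloro away raised the number. Compound 4 goes the other way, bringing in two chlorines while the methoxy leaves, so a fall of similar or somewhat larger size is expected. For compound 4 the number in this assay is estimated at 72%, between 50% and 92%, which would be a step of a number 24 percentage points lower from compound 1 to compound 4 (beyond the scatter).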

Compound 4, a percentage reported as activity, at one concentration (the size of the read-out at that concentration, not a potency): 97.8%
Beside the measured number, compound 4's estimate is 25.8 percentage points below it; the whole stated range lies below it.
By their numbers in this assay, from the lowest: compound 2; then compound 3; then compounds 1 and 4 (each within the scatter of the next).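

In this assay, putting 2,4-dichlorophenyl in place of 4-methoxyphenyl on this aromatic carbon gives a number 1.8 percentage points higher from compound 1 to compound 4 (within the scatter) and so leaves the two compounds indistinguishable. The chloro step seen on the other core, a number 15.1 percentage points higher from compound 2 to compound 3 (beyond the scatter), therefore does not carry over to this position and this change. Two things differ at once here, the methoxy leaving and two chlorines entering, so this single pair cannot show what each does alone, and nothing measured here gives a reason for the result.

The compounds shown leave open how a plain phenyl or a phenyl with a single chloro would read on this carbon of the shared core. They also leave open whether a different kind of group here, such as a dimethylamino-substituted phenyl or a carboxylic acid on the ring, would move the number at all.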